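A few compounds are considered here, and "the series" means these few. Any claim that something is new, unique, unknown or untested is made for them only; others in the source may bear on it.

Of the compounds shown here, three sharing one core have been tested in an ADME assay on MT4 cells (Homo sapiens) for cytotoxicity, with a stated time of 5 days; a higher number here means that more compound is tolerated, a lower number that less compound is tolerated. Compound 1 (`CC(C)(C)C#Cc1cc(N(C(=O)[C@H]2CC[C@H](C)CC2)[C@H]2CC[C@](O)(CO[C@H]3CCOC3)CC2)c(C(=O)O)s1`) gives 8980 nM, and compound 2 (`CC(C)(C)C#Cc1cc(N(C(=O)[C@H]2CC[C@H](C)CC2)[C@H]2CC[C@@H](Oc3ccc(=O)[nH]n3)CC2)c(C(=O)O)s1`) gives 2170 nM. Compound 3 (`CC(C)(C)C#Cc1cc(N(C(=O)[C@H]2CC[C@H](C)CC2)[C@H]2CC[C@H](OC3CCOCC3)CC2)c(C(=O)O)s1`) gives 1990 nM, which is within the scatter of compound 2 and beyond the scatter of compound 1, so it belongs to the lower pair. Compound 4 (`CC(C)(C)C#Cc1cc(N(C(=O)[C@H]2CC[C@H](C)CC2)[C@H]2CC[C@H](Oc3ccncn3)CC2)c(C(=O)O)s1`) differs from compound 3 in one place: pyrimidin-4-yl in place of oxan-4-yl on an oxygen on a saturated carbon. Among the compounds with values here, no measured pair shows this kind of change, so the expectation is a loose one. No shift beyond the scatter is expected in this assay, and the estimated step is a slight rise, a 1.5-fold higher number from compound 3 to compound 4 (0.18 log units; within the scatter). Compound 4 is estimated at 3000 nM, with an expected range of 1500 nM to 7500 nM.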

Compound 4, half-maximal cytotoxic concentration: 599 nM
Estimate against measurement, compound 4: 5.0-fold (0.70 log units) above, outside the stated range (below it).
By their numbers in this assay, from the lowest: compound 4; then compounds 3 and 2 (each within the scatter of the next); then compound 1.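

In this assay, the group on this oxygen on a saturated carbon can move the number beyond the scatter: pyrimidin-4-yl in place of oxan-4-yl gives a 3.3-fold lower number from compound 3 to compound 4 (0.52 log units; beyond the scatter), the only single-place step shown. With the heavy-atom count unchanged, the aromatic ring with two hetero atoms is tolerated less than the saturated ring. Nothing available accounts for this step. As far as these compounds go, it remains open whether a phenyl or pyridin-2-yl group on the same oxygen would give a number nearer that of compound 3 or that of compound 4. From the compounds shown here alone, a piperidin-4-yl group at this place also remains untested by these compounds.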